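This account rests on a few compounds, and the source may have more. Where it says the series, first, only, none or still open, it means among the compounds named here.

Working notes on the series. In a functional assay on A-431 cells (Homo sapiens) for antiproliferative activity, read by sulforhodamine B assay, with a stated time of 72 h (on this read-out higher numbers stand for weaker inhibition and lower numbers for stronger inhibition), compound 1 `C=C1CC(CBr)(c2ccccc2)OC1=O` gives 1480 nM and compound 2 `C=C1C[C@](CBr)(c2ccccc2)OC1=O` gives 1330 nM. For the measured compounds named here, these are the only two numbers so far, and they lie within the scatter of each other, so compound 1 stands level with its one neighbour. Going by the values given here, the single measured step is a 1.1-fold lower number from compound 1 to compound 2 (0.05 log units; within the scatter). Among the compounds with values here, it reflects the fact that one of compounds 1 and 2 is drawn with a defined configuration and the other without, at the place where they differ and is the only step available.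

Compound 3 `C=C1CC(CBr)(c2ccccc2C)OC1=O` keeps the core of compound 1 and differs in one place: methyl in place of hydrogen on an aromatic carbon. This is methyl in place of hydrogen on an aromatic carbon, ortho to a group of 9 heavy atoms. Within the data shown here, no measured step involves any change on the aromatic ring, so the data give neither a size nor a direction for this change. The working expectation in this assay is therefore no step beyond the scatter, anchored on compound 1 at 1480 nM, with a wide margin on both sides. For compound 3 the expected value is 1500 nM, with an estimated range of 600 nM to 3800 nM. The expected step is a 1.0-fold higher number from compound 1 to compound 3 (0.01 log units; within the scatter).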

Compound 3, half-maximal inhibitory concentration: 5500 nM
Estimate against measurement, compound 3: 3.7-fold (0.56 log units) below, outside the stated range (above it).
By their numbers in this assay, from the lowest: compounds 2 and 1 (each within the scatter of the next); then compound 3.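

In this assay, methyl in place of hydrogen on an aromatic carbon, ortho to a group of 9 heavy atoms, gives a 3.7-fold higher number from compound 1 to compound 3 (0.57 log units; beyond the scatter) and so moves the read-out towards weaker inhibition. This position on the aromatic ring is therefore not indifferent to substitution: a methyl alone is enough to carry the number beyond the scatter. For the compounds shown here, the earlier step concerned only how a stereocentre is drawn and stayed within the scatter, which leaves this as the only step so far that shifts the read-out and the only measure of any change on the ring. Nothing in the evidence at hand bears on the reason for this step.

The compounds shown leave open whether the loss belongs to this position on the ring or to methyl as a group, and whether methyl elsewhere on the ring would give a step of similar size or direction. From the compounds shown here alone, it also remains open whether a chlorine, a methoxy or an ethyl at this same place would follow methyl, and whether the step would hold on the defined configuration of compound 2.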